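The compounds below may be only part of what the source reports. "The series", "measured", "known", "first", "only" and "open" are said of these compounds alone.

Measured compounds:
compound 1, `COc1cc(/C=N/NC(=O)CSc2nc3ccccc3s2)cc(OC)c1OC` — > 80 ug/mL (a limit)
compound 2, `O=C(N/N=C/c1c[nH]c2ccccc12)c1ccc(CSc2nc3ccccc3s2)cc1` — > 80 ug/mL (a limit)

In a functional assay on HepG2 cells (Homo sapiens) for inhibition, read by MTT assay, with a stated time of 72 h (a lower number here means a stronger inhibitor, a higher number a weaker inhibitor), compound 1 gives > 80 ug/mL, which is a limit of the assay and not a number. Compound 2 likewise gives > 80 ug/mL, also a limit. Both shown values sit at the limit of > 80 ug/mL in this assay, at which 2 of the 2 values shown sit, so compound 2 stands at the ceiling with no number to place it. Compound 3 `Cc1cc(C)nc(SCc2ccc(C(=O)N/N=C/c3c[nH]c4ccccc34)cc2)n1` differs from compound 2 in one place: 4,6-dimethylpyrimidin-2-yl in place of 1,3-benzothiazol-2-yl on a sulfur. For the measured compounds named here, no step between measured compounds is known here, so the expected step of a number no higher from compound 2 to compound 3 (the limit leaves the size open) is none beyond the scatter. Compound 3 is accordingly estimated at 80 ug/mL, within a range from 40 ug/mL to 160 ug/mL, most likely reported again only as a limit.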

Compound 3, half-maximal inhibitory concentration: 34.1 ug/mL
Estimate against measurement, compound 3: 2.3-fold (0.37 log units) above, and the stated range ends above it.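

Placing 4,6-dimethylpyrimidin-2-yl in place of 1,3-benzothiazol-2-yl on a sulfur gives, in this assay, an at least 2.3-fold lower number from compound 2 to compound 3 (0.37 log units; beyond the scatter). The earlier compounds shown here showed no number at all, whereas this single exchange shows that the group on this sulfur can move the read-out off the limit. The step has no upper size, because compound 2 stands at a limit: the limit of > 80 ug/mL in this assay, at which 2 of the 3 values shown sit.

As far as these compounds go, it remains open whether an unsubstituted pyrimidin-2-yl, without the two methyl groups, or a plain phenyl on the sulfur would give a similar number. From the compounds shown here alone, it also remains open whether the same exchange would carry over to the core of compound 1.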